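This account rests on a few compounds, and the source may have more. Where it says the series, first, only, none or still open, it means among the compounds named here.

Notes on amide variants of a shared core, starting from compound 1 (`CCCCCCCCCCCC[C@@H](O)[C@H]1CC[C@H]([C@H](O)CCCCCCCCCCNC(=O)c2ccco2)O1`) and compound 2 (`CCCCCCCCCCCC[C@@H](O)[C@H]1CC[C@H]([C@H](O)CCCCCCCCCCNC(=O)c2ccsc2)O1`). In a functional assay on HT-29 cells (Homo sapiens) for inhibition, read by colorimetric assay and sulforhodamine B assay, with a stated time of 48 h (on this read-out lower numbers stand for stronger inhibition of growth and higher numbers for weaker inhibition of growth), compound 1 gives 100000 nM and compound 2 gives 1910 nM, the lower of the two numbers. Within the data shown here, the only measured step is a 52-fold lower number from compound 1 to compound 2 (1.72 log units; beyond the scatter), with thiophen-3-yl in place of furan-2-yl on a carbonyl carbon.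

Compound 3 (`CCCCCCCCCCCC[C@@H](O)[C@H]1CC[C@H]([C@H](O)CCCCCCCCCCNC(=O)c2ccnn2C)O1`) has 1-methyl-1H-pyrazol-5-yl in place of thiophen-3-yl on a carbonyl carbon. The measured step bears on this change as the same kind of exchange at the same place, and it shows that this assay can respond strongly to the ring held there. Among the measured compounds shown here, it is a single pair, however, and no measured compound carries a pyrazole-type ring, so size and direction remain poorly defined.

Since compound 2 has the lower number of the pair at 1910 nM, a moderate move to a higher number is expected, smaller than the measured step. The expected change is a 4.7-fold higher number from compound 2 to compound 3 (0.67 log units; beyond the scatter). For compound 3 the estimated value is 9000 nM, with an expected range of 1500 nM to 50000 nM.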

Compound 3, concentration for 50% growth inhibition: 100000 nM
Estimate against measurement, compound 3: 11-fold (1.05 log units) below; measured number above the stated range.
By their numbers in this assay, from the lowest: compound 2; then compounds 1 and 3 (each within the scatter of the next).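

In this assay, the ring on the carbonyl carbon now moves the number in both directions: 1-methyl-1H-pyrazol-5-yl in place of thiophen-3-yl gives a 52-fold higher number from compound 2 to compound 3 (1.72 log units; beyond the scatter), so the lower number of compound 2 is not shared by every five-membered aromatic ring placed there. The exchange of 1-methyl-1H-pyrazol-5-yl for furan-2-yl gives no change at the digits printed from compound 1 to compound 3 (within the scatter), which leaves thiophen-3-yl as the only ring among these three compounds that stands apart. The exchange from compound 2 to compound 3 replaces sulfur with two ring nitrogens and also adds a methyl group, so this one pair cannot assign the large step to any single part of the change.

Going by these compounds, it remains open whether the low number in compound 2 is specific to thiophen-3-yl or would extend to thiophen-2-yl, phenyl, or an unmethylated pyrazole on the same carbonyl carbon. The data at hand offer no measurement that explains the separation of thiophen-3-yl from the other two rings.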